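Compound 3 to compound 4: benzylamino to anilino exchange

The source may hold more compounds than are shown below. What is called first, only, known or untested is meant among the compounds shown, and "the series" means these compounds.

Measured in a functional assay on MDA-MB-231 cells (Homo sapiens) for inhibition, read by CCK-8 assay, with a stated time of 48 h; a lower number here means a stronger inhibitor of growth, a higher number a weaker inhibitor of growth:
- compound 1 `Cc1ccccc1Nc1nc(Nc2ccc(N3CCCCC3)cc2)ncc1Cl` gives 19900 nM
- compound 2 `Cc1ccccc1Nc1nc(Nc2ccc(N3CCCN(C)CC3)cc2)ncc1Cl` gives 6390 nM
- compound 3 `Cc1ccc(CNc2nc(Nc3ccc(N4CCN(C)CC4)cn3)ncc2Cl)cc1` gives 18600 nM

Compound 3 lies within the scatter of compound 1, and its number is higher than that of compound 2 by more than the scatter. In compound 4 `CCc1ccc(Nc2nc(Nc3ccc(N4CCN(C)CC4)cn3)ncc2Cl)cc1`, 4-ethylphenyl stands in place of 4-methylbenzyl on a nitrogen on an aromatic ring (4-ethylphenyl in place of 4-methylbenzyl on a nitrogen on an aromatic ring). Going by the values given here, no measured step covers this exchange. Among the compounds with values here, the only measured step, a 3.1-fold lower number from compound 1 to compound 2 (0.49 log units; beyond the scatter), is a change at another place, so it serves only as a guide to size. It suggests that a single change here need not move the number far. A small shift towards a lower number in this assay is expected, about at the edge of the scatter, though the data give little support for its direction. The expected change is a 1.7-fold lower number from compound 3 to compound 4 (0.23 log units; within the scatter). For compound 4 the estimated value is 11000 nM, with an expected range of 4000 nM to 27000 nM.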

Compound 4, concentration for 50% growth inhibition: 5560 nM
Beside the measured number, compound 4's estimate is 2.0-fold (0.30 log units) above it; measured number inside the range.
By their numbers in this assay, from the lowest: compounds 4 and 2 (each within the scatter of the next); then compounds 3 and 1 (each within the scatter of the next).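

In this assay, going by these compounds alone, the exchange of 4-methylbenzyl for 4-ethylphenyl on the nitrogen gives a 3.3-fold lower number from compound 3 to compound 4 (0.52 log units; beyond the scatter), the first measured change at this position. The two groups have the same heavy-atom count and the same ring, and neither carries a hydrogen-bond donor or acceptor, so the number here responds to how these carbons are joined, not only to what is counted. Nothing available explains this shift.

The compounds shown leave open whether the lower number goes with the aryl group sitting directly on the nitrogen or with the ethyl group, as these two features change together in this single step. A 4-methylphenyl or 4-ethylbenzyl group on the same nitrogen would separate them, and a 4-aminophenyl group would test whether the ethyl group can be replaced at all.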